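Trifluoromethyl for Methyl on a Fused Imidazopyridine Core

The source may hold more compounds than are shown below. What is called first, only, known or untested is meant among the compounds shown, and "the series" means these compounds.

Measured compounds:
compound 1, `OCc1c(C(F)(F)F)nc2c(OCc3ccccc3)cccn12`, 2
compound 2, `Cc1nc2c(OCc3ccccc3)cccn2c1C`, 7

Of the compounds shown here, two of the shared core have been measured in a physicochemical assay for acid dissociation. Compound 2 `Cc1nc2c(OCc3ccccc3)cccn2c1C` gives 7, the higher of the two numbers. For the measured compounds named here, compound 1 `OCc1c(C(F)(F)F)nc2c(OCc3ccccc3)cccn12` gives 2, a value far lower than that of compound 2 and well beyond the scatter; the two structures differ in more than one place, so no single step links them.

Compound 3 `Cc1c(C(F)(F)F)nc2c(OCc3ccccc3)cccn12` differs from compound 2 in one place only: trifluoromethyl in place of methyl on an aromatic carbon. Going by the values given here, no step between measured compounds shows this change on its own. Still, compound 1 also carries a trifluoromethyl where compound 2 carries a methyl, and compound 1 gives 2, so a large drop is expected in this assay, clearly beyond the scatter. The expected step from compound 2 to compound 3 is a number 3.70 log units lower from compound 2 to compound 3 (beyond the scatter). Compound 3 is therefore estimated at 3.3, with a range from 2.3 to 4.3.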

Compound 3, acid dissociation constant: 2
Estimate against measurement, compound 3: 1.30 log units above; measured number outside the range, below it.
By their numbers in this assay, from the lowest: compounds 1 and 3 (each within the scatter of the next); then compound 2.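

In this assay, trifluoromethyl in place of methyl on an aromatic carbon of the five-membered ring can now be read as a single change, and it gives a number 5.00 log units lower from compound 2 to compound 3 (beyond the scatter), a large step at this position. Hydrogen in place of hydroxy on the saturated chain carbon gives no change at the digits printed from compound 1 to compound 3 (within the scatter), so with trifluoromethyl present, this pair shows no effect of that hydroxy group on the read-out. No measurement shown accounts for the size of the step.

As far as these compounds go, at this position, only methyl and trifluoromethyl can be compared so far, so it remains open how a nitrile, an amine or a longer chain such as ethyl would compare. From the compounds shown here alone, it is also open whether the hydroxy group would still make no difference with methyl in place of trifluoromethyl.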